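Same Core, New Amide Group: Expecting Another Limit

The compounds below may be only part of what the source reports. "The series", "measured", "known", "first", "only" and "open" are said of these compounds alone.

Compound 1 `CCN(CC)S(=O)(=O)c1ccc(S(=O)(=O)N2CCC[C@@H](C(=O)NC3CN(C(=O)C4CC4)C3)C2)cc1` is one of two measured members of a shared core bearing a bis-sulfonyl aryl group. In a functional assay on MIA PaCa-2 cells (Homo sapiens) for inhibition, read by MTT assay, with a stated time of 3 days (a higher number here means a weaker inhibitor, a lower number a stronger inhibitor), compound 1 gives > 10000 nM, which is a limit of the assay rather than a measured number. Compound 2 `CC(C)c1noc(N2CCN(C(=O)[C@@H]3CCCN(S(=O)(=O)c4ccc(S(=O)(=O)NC(C)(C)C)cc4)C3)CC2)n1` shares that core, and in this assay compound 2 gives > 10000 nM, again only a limit. Within the data shown here, both measured values thus sit at the limit of > 10000 nM in this assay, at which 2 of the 2 values shown sit, so no measured step between them exists and no trend can be read from the two. Compound 3 `CCN(CC)S(=O)(=O)c1ccc(S(=O)(=O)N2CCC[C@@H](C(=O)N3CCN(c4nc(C)no4)CC3)C2)cc1` is made from compound 1 by a single change at the carbonyl carbon: 4-(3-methyl-1,2,4-oxadiazol-5-yl)piperazin-1-yl in place of (1-(cyclopropylcarbonyl)azetidin-3-yl)amino on a carbonyl carbon. Among the measured compounds shown here, with no measured step to lean on, the expected step is a step that the limit leaves unreadable from compound 1 to compound 3, meaning none beyond the usual scatter. Compound 3 is therefore estimated to remain weak, at about 15000 nM with a range from 5000 nM to 50000 nM.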

Compound 3, half-maximal inhibitory concentration: > 10000 nM
Compound 3 was reported as a limit; the forecaster's own chance of this, stated with the estimate: 80%; the middle value lies beyond the limit too.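

Compound 1 and compound 3 are both reported only as limits, so no step can be read between them: the limit of > 10000 nM in this assay, at which 3 of the 3 values shown sit.

The compounds shown leave open whether any group on this carbonyl carbon of the shared core gives a measurable value in this assay.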